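Carboxylic acid in place of methoxy on a cytotoxicity screen

This account rests on a few compounds, and the source may have more. Where it says the series, first, only, none or still open, it means among the compounds named here.

Two compounds built on a shared core, compound 1 `O=c1n(Cc2nc3nc(Cl)ccc3n2CCCCF)c2cnccc2n1C1CC1` and compound 2 `COc1ccc(-n2c(=O)n(Cc3cc4cc(Cl)ccc4n3CCCC#N)c3cnccc32)cc1`, were tested in an ADME assay on HeLa cells (Homo sapiens) for cytotoxicity, read by ATP content, with a stated time of 3 days; a lower number here means that less compound is tolerated, a higher number that more compound is tolerated. In this assay compound 1 gives > 50000 nM, which is a limit of the measurement rather than a number. Compound 2 likewise reaches only a limit, > 50000 nM. Compound 2 therefore stands where every value shown sits: the limit of > 50000 nM in this assay, at which 2 of the 2 values shown sit. The next compound, compound 3 `N#CCCCn1c(Cn2c(=O)n(-c3ccc(C(=O)O)cc3)c3ccncc32)cc2cc(Cl)ccc21`, differs from compound 2 in one place: carboxy in place of methoxy on an aromatic carbon. Among the measured compounds shown here, no measured pair shows how this change moves the cytotoxicity, and nothing here shows any compound being tolerated less than the limit allows. The step that the limit leaves unreadable from compound 2 to compound 3 is therefore expected to be none beyond the scatter. Compound 3 is estimated to give 60000 nM in this assay, with a likely range from 30000 nM to 150000 nM.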

Compound 3, half-maximal cytotoxic concentration: > 50000 nM
Compound 3 ended at the assay's limit; the forecaster's own chance of this, stated with the estimate: 80%; the middle value does not contradict the limit.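

Compound 2 and compound 3 both end at a limit of the measurement rather than a number, so no step between them can be read: the limit of > 50000 nM in this assay, at which 3 of the 3 values shown sit.

The compounds shown leave open whether carboxy in place of methoxy changes cytotoxicity at all, and what concentration of any of them would harm the cells.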